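The compounds below may be only part of what the source reports. "The series", "measured", "known", "first", "only" and "open" are said of these compounds alone.

Of the compounds shown here, three have so far been measured in a functional assay on MCF7 cells (Homo sapiens) for inhibition, read by MTT assay, with a stated time of 72 h; a lower number here means a stronger inhibitor, a higher number a weaker inhibitor. Compound 1 `Cc1cc(Nc2cc(-c3ccccc3)[nH]n2)n2nc(SCc3ccc(Cl)cc3)nc2n1` gives 8260 nM in this assay, the highest of the three numbers. Compound 2 `CCCCCc1c(C)nc2nc(SCc3ccc(Cl)cc3)nn2c1Nc1cc(-c2ccccc2)[nH]n1` gives 6390 nM, and the step of a 1.3-fold lower number from compound 1 to compound 2 (0.11 log units; within the scatter) corresponds to pentyl in place of hydrogen on an aromatic carbon. Compound 3 `Cc1cc(Nc2ccn(Cc3ccc(C(F)(F)F)cc3)n2)n2nc(SCc3ccc(Br)cc3)nc2n1` differs from compound 1 in several places at once. In this assay compound 3 gives 2280 nM. Set against compound 1 this value shows a gap beyond the scatter, but with several changes at once no single change can be read from it.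

Compound 4 `C=CCSc1nc2nc(C)cc(Nc3cc(-c4ccccc4)[nH]n3)n2n1` has not yet been measured. It differs from compound 1 in a single place: vinyl in place of 4-chlorophenyl on a saturated chain carbon bound to a sulfur Cut one bond further out, the (4-chlorobenzyl)sulfanyl group becomes an allylsulfanyl group. Within the data shown here, none of the measured steps touches this part of the shared core; the only single step, that between compound 1 and compound 2, sits elsewhere and lies within the scatter. The expectation for compound 4 in this assay is therefore anchored by nothing more than the value of compound 1, and is estimated as a 1.5-fold higher number from compound 1 to compound 4 (0.16 log units; within the scatter), leaning toward a higher number. Compound 4 is expected to give about 12000 nM, with a range from 4000 nM to 40000 nM.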

Compound 4, half-maximal inhibitory concentration: > 50000 nM
Compound 4 ended at the assay's limit; the forecaster's own chance of this, stated with the estimate: 20%; at least 4.1-fold (0.61 log units) between middle value and limit.
By their numbers in this assay, from the lowest: compound 3; then compounds 2 and 1 (each within the scatter of the next). At a limit, above all of these: compound 4.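

In this assay, the group on the sulfur turns out to matter, a part of the molecule that the earlier single step did not touch: the exchange of 4-chlorobenzyl for allyl gives an at least 6.0-fold higher number from compound 1 to compound 4 (0.78 log units; beyond the scatter), beyond the scatter, whereas the pentyl step elsewhere on the shared core stayed within it. Going by these compounds, compound 4 stands at a limit of the assay and not at a number, so this step fixes only a smallest size and its full size stays unknown: the limit of > 50000 nM in this assay, at which 1 of the 4 values shown sits. In this one pair, the (4-chlorobenzyl)sulfanyl group of compound 1 goes with a measurable inhibition, while the allylsulfanyl group of compound 4 does not reach a number.

The single change takes away the aromatic ring and the chlorine together, and the compounds shown cannot separate the two. On these data alone, how a plain benzyl group, a 4-methoxybenzyl group or a longer chain such as hexyl on the sulfur would fare in this assay remains open.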